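The source may hold more compounds than are shown below. What is called first, only, known or untested is meant among the compounds shown, and "the series" means these compounds.

Of the compounds shown here, three sharing one core have been measured in an assay on isolated protein for binding affinity to adenosine receptor A1 (Bos taurus); a lower number here means a stronger inhibitor, a higher number a weaker inhibitor. Compound 1 `CCCCCCNc1nc(-c2ccccc2)nc2c1nnn2Cc1ccccc1Cl` gives 31000000 nM. Compound 2 `Clc1ccccc1Cn1nnc2c(NC3CCCCC3)nc(-c3ccccc3)nc21` gives 34000000 nM in this assay. Compound 3 `OCCCNc1nc(-c2ccccc2)nc2c1nnn2Cc1ccccc1Cl` gives 33000000 nM in this assay. Compound 3 stands second highest of these numbers, its nearest neighbour being compound 2 and its furthest compound 1, and every step among the three lies within the scatter: a 1.1-fold higher number from compound 1 to compound 2 (0.04 log units; within the scatter), a 1.1-fold higher number from compound 1 to compound 3 (0.03 log units; within the scatter) and a 1.0-fold lower number from compound 2 to compound 3 (0.01 log units; within the scatter). Compound 4 `OCCNc1nc(-c2ccccc2)nc2c1nnn2Cc1ccccc1Cl` differs from compound 3 by hydroxy in place of hydroxymethyl on a saturated chain carbon, two bonds along the chain from a nitrogen on an aromatic ring. The step bearing most closely on this change is a 1.1-fold higher number from compound 1 to compound 3 (0.03 log units; within the scatter), which also altered the same chain and left the number within the scatter; the exchanges of the whole chain in a 1.1-fold higher number from compound 1 to compound 2 (0.04 log units; within the scatter) and a 1.0-fold lower number from compound 2 to compound 3 (0.01 log units; within the scatter) likewise moved nothing beyond it. No step beyond the scatter is therefore expected here. For compound 4 the expected step is no change at the digits printed from compound 3 to compound 4 (within the scatter). For compound 4 the estimate in this assay is 33000000 nM, with a range from 15000000 nM to 70000000 nM.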

Compound 4, inhibition constant: 116000000 nM
Estimate against measurement, compound 4: 3.5-fold (0.55 log units) below; the whole stated range lies below it.
By their numbers in this assay, from the lowest: compounds 1, 3 and 2 (each within the scatter of the next); then compound 4.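

In this assay, going by these compounds alone, shortening (3-hydroxypropyl)amino to (2-hydroxyethyl)amino gives a 3.5-fold higher number from compound 3 to compound 4 (0.55 log units; beyond the scatter), the first step beyond the scatter at this position. Replacing the other groups on this nitrogen with 2-hydroxyethyl gives much the same result, with a 3.4-fold higher number from compound 2 to compound 4 (0.53 log units; beyond the scatter) for cyclohexyl and a 3.7-fold higher number from compound 1 to compound 4 (0.57 log units; beyond the scatter) for hexyl, so among these four compounds only the 2-hydroxyethyl group stands apart. The hydroxy group alone does not account for this separation, since compound 3 also carries one and stays within the scatter of compound 1 and compound 2, and no measurement given here offers an explanation for the step.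

The compounds shown leave open whether the higher number follows from the shorter chain or from the hydroxy group at its end. A plain ethyl chain or a 2-aminoethyl chain on the same nitrogen would separate these two readings.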